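Nitro for amino on the styryl sulfone series

The compounds below may be only part of what the source reports. "The series", "measured", "known", "first", "only" and "open" are said of these compounds alone.

Working notes on three measured compounds and one to be measured in a functional assay on HCT-116 cells (Homo sapiens) for cytotoxicity, read by MTT assay, with a stated time of 72 h; on this read-out higher numbers stand for weaker inhibition of growth and lower numbers for stronger inhibition of growth. Compound 1 `COc1cc(OC)c(/C=C/S(=O)(=O)Cc2ccc(OC)c(N)c2)c(OC)c1` carries the amino group and in this assay gives < 10 nM, which is a limit of the assay and not a number (the limit of < 10 nM in this assay, at which 1 of the 3 values shown sits). Compound 2 `COc1ccc(CS(=O)(=O)CC(=O)Nc2c(C)cc(C)cc2C)cc1N` in this assay gives > 30000 nM, again a limit of the assay rather than a number (the limit of > 30000 nM in this assay, at which 1 of the 3 values shown sits). Compound 3 `COc1cc(OC)c(NC(=O)CS(=O)(=O)Cc2ccc(OC)c([N+](=O)[O-])c2)c(OC)c1` in this assay gives 18800 nM. Within the data shown here, compound 1 thus sits at the strong end of what the assay reports, and compound 3 sits far from it; compound 3 differs from compound 1 in more than one place, so no single step between them is set out.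

Compound 4 `COc1cc(OC)c(/C=C/S(=O)(=O)Cc2ccc(OC)c([N+](=O)[O-])c2)c(OC)c1` is compound 1 with the change (nitro in place of amino on an aromatic carbon), nitro in place of amino on an aromatic carbon. Among the measured compounds shown here, no measured step isolates this change. The expectation is a step from compound 1 to compound 4 in this assay toward weaker growth inhibition, of modest size and possibly no larger than the scatter, estimated as an at least 5.0-fold higher number from compound 1 to compound 4 (0.69 log units; beyond the scatter). Compound 4 is expected at about 50 nM, with a range from 5 nM to 500 nM.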

Compound 4, concentration for 50% growth inhibition: 660 nM
For compound 4 the middle estimate is 13-fold (1.12 log units) below the measured one, and the stated range ends below it.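

Notes on the result: on the core of compound 1, nitro in place of amino on an aromatic carbon, ortho to a methoxy group, is now isolated as a single change, and in this assay it is a large one (an at least 66-fold higher number from compound 1 to compound 4 (1.81 log units; beyond the scatter)). This position therefore matters for growth inhibition on this core, yet compound 4 with the nitro group still gives 660 nM, so amino is not required for activity in the nanomolar range. From the compounds shown here alone, compound 1 gives a limit and not a number, so the full size of the step stays unknown: the limit of < 10 nM in this assay, at which 1 of the 4 values shown sits.

Open, going by these compounds, is how a hydroxyl or an acetamide group at this position would compare with amino and nitro. Also open, on these data alone, is whether the change carries a similar step on the amide-linked compounds, as compound 2 and compound 3 differ in more than one place.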